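Benzyl to 2-fluorophenyl on the amine of a thiophene core

This account rests on a few compounds, and the source may have more. Where it says the series, first, only, none or still open, it means among the compounds named here.

Measured compounds:
compound 1, `CC(C)Nc1sc(C(=O)c2ccc(Cl)s2)c(N)c1C#N`, 192 nM
compound 2, `N#Cc1c(NCc2ccccc2)sc(C(=O)c2ccc(Cl)s2)c1N`, > 5000 nM

Of the compounds shown here, two sharing one core have been measured in an assay for inhibition of Maternal embryonic leucine zipper kinase (Homo sapiens), read by ADP-Glo, with a stated time of 0.5 h; on this read-out lower numbers stand for stronger inhibition and higher numbers for weaker inhibition. Compound 1 gives 192 nM. For compound 2 the result is only a limit, > 5000 nM. Within the data shown here, the one step between measured compounds, an at least 26-fold higher number from compound 1 to compound 2 (1.41 log units; beyond the scatter), is large, and compound 2 sits at the limit of > 5000 nM in this assay, at which 1 of the 2 values shown sits, so its true position is not known beyond that bound.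

The next compound, compound 3, `N#Cc1c(Nc2ccccc2F)sc(C(=O)c2ccc(Cl)s2)c1N`, differs from compound 2 in one place: 2-fluorophenyl in place of benzyl on a nitrogen on an aromatic ring. Among the measured compounds shown here, no measured step covers this kind of change. For the measured compounds named here, the only step known, an at least 26-fold higher number from compound 1 to compound 2 (1.41 log units; beyond the scatter), shows that the group on this nitrogen can move the number a great deal, but it says nothing about an aryl group in place of a benzyl group. Because compound 2 gives only > 5000 nM, any step from it is also uncertain on its starting side.

Compound 3 is therefore expected to lie near 3000 nM, within 300 nM to 20000 nM, which means an expected step of an at least 1.6-fold lower number from compound 2 to compound 3 (0.22 log units; that floor lies within the scatter).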

Compound 3, half-maximal inhibitory concentration: 707 nM
Compound 3: middle estimate off by 4.2-fold (0.63 log units), on the high side, and the stated range covers the measured number.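

On this nitrogen in this assay, 2-fluorophenyl in place of benzyl gives an at least 7.0-fold lower number from compound 2 to compound 3 (0.84 log units; beyond the scatter), although the two groups match in counting 7 heavy atoms and one six-membered aromatic ring, so neither that count nor the ring alone sets the number. The size of this step is only a floor, because compound 2 stands at a limit: the limit of > 5000 nM in this assay, at which 1 of the 3 values shown sits. Isopropyl nevertheless keeps the lead over 2-fluorophenyl, with a 3.7-fold higher number from compound 1 to compound 3 (0.57 log units; beyond the scatter), so the aryl group recovers much of what was lost with benzyl but does not reach the level of the branched alkyl group.

What the fluorine itself contributes remains open, as the compounds shown include no plain phenyl on this nitrogen and no other fluorophenyl isomer for comparison. From the compounds shown here alone, it is also open whether an ethyl group, a cyclopropyl group or a longer chain on this nitrogen would improve on compound 1, which gives 192 nM, and whether the trend would hold with an amide in place of the nitrile on the shared core.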